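Series solubility notes: from compound 3 toward compound 4

A few compounds are considered here, and "the series" means these few. Any claim that something is new, unique, unknown or untested is made for them only; others in the source may bear on it.

Measured compounds:
- compound 1 `Cc1cc(C)cc(NC(=O)COc2cc(C)nc3ccc(OCc4ccccc4)cc23)c1`: in a physicochemical assay for solubility, in phosphate buffer, measured as kinetic solubility, with a stated time of 1 h, at pH 7.4 (on this read-out lower numbers stand for lower solubility and higher numbers for higher solubility), compound 1 gives < 1000 nM
- compound 2 `COc1ccc2nc(C)cc(OCCNc3cc(C)cc(C)c3)c2c1`: in this assay compound 2 gives 33000 nM
- compound 3 `COc1ccc2nc(C)cc(OCC(=O)Nc3cccc(C)c3)c2c1`: in this assay compound 3 gives 193000 nM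

The value given for compound 1 is a limit of this assay rather than a number, (the limit of < 1000 nM in this assay, at which 1 of the 3 values shown sits). Among the two numbers shown, compound 3 holds the higher one; the nearest, compound 2, lies well below it, beyond the scatter.

Compound 4 `COc1ccc2nc(C)cc(OCC(=O)Nc3ccncc3)c2c1` is not yet measured. It differs from compound 3 in one place: pyridin-4-yl in place of 3-methylphenyl on an amide-type nitrogen. Going by the values given here, no measured pair in this set carries the same change, so the step has no direct precedent here.

The step from compound 3 to compound 4 in this assay is expected to be a 2.3-fold higher number from compound 3 to compound 4 (0.37 log units; beyond the scatter), upward and beyond the scatter. Compound 4 is estimated at 450000 nM, with a range from 150000 nM to 1200000 nM.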

Compound 4, solubility: 91500 nM
Beside the measured number, compound 4's estimate is 4.9-fold (0.69 log units) above it; measured number outside the range, below it.
By their numbers in this assay, from the lowest: compound 2; then compound 4; then compound 3. At a limit, below all of these: compound 1.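

Going by these compounds alone, this is the first one-place comparison: on the amide-type nitrogen, pyridin-4-yl in place of 3-methylphenyl gives a 2.1-fold lower number from compound 3 to compound 4 (0.32 log units; beyond the scatter) in this assay, a modest step. With the shared core held constant, the swap to an aromatic ring with a hetero atom therefore lowers the number rather than raising it. Nothing measured here bears on the reason for this step.

The change removes the methyl and brings in the ring nitrogen together, and the compounds shown cannot separate the two. Plain phenyl or pyridin-3-yl on the same nitrogen would help to separate them.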